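Swapping an Ethyl Group for Fluorine and Methyl

The compounds below may be only part of what the source reports. "The series", "measured", "known", "first", "only" and "open" are said of these compounds alone.

For the measured compounds named here, compound 1, `CCc1cccc(Nc2cc(NC(=O)Nc3cc(OC)cc(OC)c3)ncn2)c1`, is one of two compounds measured in a functional assay on PC-9 cells (Homo sapiens) for inhibition, read by MTT assay, with a stated time of 48 h, tested at 10 uM; a higher number here means more inhibition at the concentration tested (going by the name of the read-out), a lower number less inhibition. In this assay compound 1 gives 82.1%, the higher of the two numbers. Compound 2, `CC(C)(C)c1ccc(Nc2cc(NC(=O)Nc3c(Cl)cccc3Cl)ncn2)cc1`, gives 41.5% in this assay, a number far enough below compound 1 to lie beyond the scatter. Compound 3, `COc1cc(NC(=O)Nc2cc(Nc3cc(C)cc(F)c3)ncn2)cc(OC)c1`, has not yet been measured. It differs from compound 1 in a single place: 3-fluoro-5-methylphenyl in place of 3-ethylphenyl on a nitrogen on an aromatic ring. Both groups sit on the same nitrogen at the edge of the shared core, and neither carries a hydrogen-bond donor or acceptor. Going by the values given here, no measured pair shows what this kind of swap does, so the step from compound 1 to compound 3 is expected to be a small loss, a number 8.1 percentage points lower from compound 1 to compound 3 (within the scatter), within or only just beyond the scatter. Compound 3 is therefore estimated at 74% in this assay, with a range from 55% to 90%.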

Compound 3, a percentage reported as inhibition, at one concentration (the size of the read-out at that concentration, not a potency): 64.5%
Compound 3: the middle estimate sits 9.5 percentage points above what was measured; the measured number falls inside the stated range.
By their numbers in this assay, from the lowest: compound 2; then compound 3; then compound 1.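

For the compounds shown here, this is the first pair of compounds that differ only in the group on this nitrogen, and in this assay the change to 3-fluoro-5-methylphenyl gives a number 17.6 percentage points lower from compound 1 to compound 3 (beyond the scatter) on the same shared core. The position therefore responds to this swap, even though the two groups have the same count of heavy atoms and neither has a hydrogen-bond donor or acceptor. Nothing available here explains why the number falls.

The swap changes several things at once, so the compounds shown cannot separate the effect of losing the ethyl group from that of adding the fluorine or the methyl. Simpler groups such as 3-methylphenyl or 3-fluorophenyl on this nitrogen, or a longer chain such as 3-propylphenyl, remain open.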